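The compounds below may be only part of what the source reports. "The series", "measured", "known", "first", "only" and "open" are said of these compounds alone.

Measured so far in a functional assay on NCI-H226 cells (Homo sapiens) for inhibition, read by MTT assay, with a stated time of 48 h, tested at 10 uM; a lower number here means less inhibition, a higher number more inhibition at the concentration tested (going by the name of the read-out):
- compound 1 `CCc1ccc(Nc2cc(NC(=O)Nc3cc(OC)cc(OC)c3)ncn2)cc1`: 50.1%
- compound 2 `Cc1ccc(Nc2cc(NC(=O)Nc3c(Cl)cccc3Cl)ncn2)cc1C`: 41.3%
- compound 3 `COc1ccc(Nc2cc(NC(=O)Nc3c(Cl)cccc3Cl)ncn2)cc1C`: 50%

Compound 3 stands second highest of the three numbers. Among the measured compounds shown here, its nearest neighbour is compound 1, whose value lies within the scatter of that of compound 3; the furthest is compound 2, and the only single-site step recorded, a number 8.7 percentage points higher from compound 2 to compound 3 (within the scatter), also stays within the scatter. The three measured compounds therefore sit in one band, and no change so far has moved this assay beyond its noise.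

Compound 4 `COc1cc(NC(=O)Nc2cc(Nc3ccc(OC)c(C)c3)ncn2)cc(OC)c1` is the next one to be measured. It differs from compound 3 at the amide-type nitrogen: 3,5-dimethoxyphenyl in place of 2,6-dichlorophenyl on an amide-type nitrogen. For the measured compounds named here, no measured step touches this position; the one step recorded concerns a methoxy in place of methyl on an aromatic carbon elsewhere, and is within the scatter. The 3,5-dimethoxyphenyl group is already present on the amide-type nitrogen of compound 1, which, with a different aryl on the other side, gives a value within the scatter of compound 3. On this basis no step beyond the scatter is expected, no change at the digits printed from compound 3 to compound 4 (within the scatter), and compound 4 is estimated at 50% with a range of 38% to 62%.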

Compound 4, a percentage reported as inhibition, at one concentration (the size of the read-out at that concentration, not a potency): 39.7%
For compound 4 the middle estimate is 10.3 percentage points above the measured one; measured number inside the range.
By their numbers in this assay, from the lowest: compounds 4, 2, 3 and 1 (each within the scatter of the next, the first and the last beyond it).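

In this assay, among the compounds shown here, the amide-type nitrogen proves to be a position where a single change can pass the scatter: 3,5-dimethoxyphenyl in place of 2,6-dichlorophenyl gives a modest step (a number 10.3 percentage points lower from compound 3 to compound 4 (beyond the scatter)), whereas the one earlier step, at another site, stayed within it. The aryl on the other nitrogen also matters with 3,5-dimethoxyphenyl held fixed: 4-methoxy-3-methylphenyl in place of 4-ethylphenyl gives a similarly modest step (a number 10.4 percentage points lower from compound 1 to compound 4 (beyond the scatter)). Nothing available explains either step.

From the compounds shown here alone, whether the change at the amide-type nitrogen gives the same step with 4-ethylphenyl on the other nitrogen remains open. Also open, going by these compounds, is what an amine or a carboxylic acid on the aryl at the amide-type nitrogen would give, and all these readings come from one concentration, so potency is unknown.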